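Adding 2-hydroxyethyl to compound 2

The source may hold more compounds than are shown below. What is called first, only, known or untested is meant among the compounds shown, and "the series" means these compounds.

In a functional assay on NCI-H1299 cells (Homo sapiens), read by flow cytometry (on this read-out higher numbers stand for an effect only at larger amounts of compound and lower numbers for an effect already at smaller amounts), compound 1 (`N#Cc1ncc2nc1OC/C=C\COc1ccc(Cl)cc1NC(=O)N2`) gives > 10000 nM as a limit and not a number. Compound 2 (`N#Cc1ncc2nc1OCC/C=C\COc1ccccc1NC(=O)N2`) gives > 10000 nM as a limit as well. Compound 3 (`CCOc1ccc2c(c1)NC(=O)Nc1cnc(C#N)c(n1)OCCCCCO2`) gives > 10000 nM as a limit too. Compound 2 thus has no number to start from, and the limit of > 10000 nM in this assay, at which 3 of the 3 values shown sit, describes the whole set. Compound 4 (`N#Cc1ncc2nc1OCC/C=C\COc1ccc(CCO)cc1NC(=O)N2`) carries 2-hydroxyethyl in place of hydrogen on an aromatic carbon of the core of compound 2. Going by the values given here, no measured step gives a scale for this change, so the expected at least 1.2-fold lower number from compound 2 to compound 4 (0.09 log units; that floor lies within the scatter) is taken as none beyond the scatter. In this assay compound 4 is estimated at 8000 nM with an expected range from 1500 nM to 20000 nM and may well report only a limit.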

Compound 4, half-maximal effective concentration: > 10000 nM
Compound 4: no number, only a limit; the forecaster's own chance of this, stated with the estimate: 60%; middle value at least 1.2-fold (0.09 log units) from the limit.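

In this assay compound 2 and compound 4 both report only limits and not numbers, so no step can be read between them. The compounds shown leave open whether 2-hydroxyethyl in place of hydrogen on an aromatic carbon changes the read-out at all, as a single limit describes the whole set: the limit of > 10000 nM in this assay, at which 4 of the 4 values shown sit.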